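The source may report more compounds than this note shows. Statements on the series, on what has been measured and on what is new or still open speak of the compounds shown alone.

Measured compounds in an ADME assay on NIH3T3 cells (Mus musculus) for cytotoxicity, read by CCK-8 assay, with a stated time of 24 h; a higher number here means a weaker inhibitor, a lower number a stronger inhibitor:

compound 1, `C/C(=C\c1cc(-c2cccnc2)co1)C(N)=O`: > 50000 nM, a limit of the assay rather than a number.
compound 2, `C/C(=C\c1cc(-c2ccc(C)cc2)cs1)C(N)=O`: > 50000 nM, again only a limit.
compound 3, `C/C(=C\c1cc(-c2ccc(C#N)cc2)cs1)C(N)=O`: > 50000 nM, again only a limit.

Compound 3 therefore stands nowhere readable on the numbers shown: it sits at the limit, as do the other two values, and the note on the measured data says as much (the limit of > 50000 nM in this assay, at which 3 of the 3 values shown sit). For the measured compounds named here, no compound can be placed against another, and the only single-point step, a step that the two limits leave unreadable from compound 2 to compound 3, runs from one limit to another and cannot be sized.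

Compound 4, `C/C(=C\c1cc(-c2ccc(Cl)cc2)cs1)C(N)=O`, is the next member of the series. It differs from compound 3 by chloro in place of cyano on an aromatic carbon. Going by the values given here, no measured step bears directly on this change; the step from compound 2 to compound 3, which touches the same position of the same ring, gave nothing readable, so there is no measured size to carry over. What the three values do show is that every variation tried on the aryl group so far has left the readout at the limit.

The expectation for compound 4 in this assay is therefore that it also sits at or beyond the limit, with the step that the limit leaves unreadable from compound 3 to compound 4 expected to be none beyond the scatter. Compound 4 is estimated at 100000 nM, with a range from 50000 nM to 300000 nM, most likely reported only as a limit.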

Compound 4, half-maximal inhibitory concentration: > 50000 nM
Compound 4: a limit, no number; the forecaster's own chance of this, stated with the estimate: 90%; the middle value is on the limit's open side.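

In this assay compound 4 gives > 50000 nM, a limit and not a number. No step from compound 2 or compound 3 to compound 4 can be read: the limit of > 50000 nM in this assay, at which 4 of the 4 values shown sit.

The compounds shown leave open how far any of them lies past the limit, and which change, if any, would give a readable half-maximal inhibitory concentration in this assay.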